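The source may report more compounds than this note shows. Statements on the series, on what has been measured and on what is new or still open speak of the compounds shown alone.

Measured in a functional assay on A549 cells (Homo sapiens) for antiproliferative activity, read by MTT assay, with a stated time of 48 h; on this read-out lower numbers stand for stronger inhibition and higher numbers for weaker inhibition:
- compound 1 `Cc1ccc(-c2cc(NC(=O)/C=C/c3ccc(C(F)(F)F)cc3)n[nH]2)cc1`: 1020 nM
- compound 2 `O=C(/C=C\c1ccc(C(F)(F)F)cc1)Nc1cc(-c2ccccc2)[nH]n1`: 880 nM
- compound 3 `COc1ccc(/C=C\C(=O)Nc2cc(-c3ccccc3)[nH]n2)cc1`: 1060 nM

In this assay, compound 1 gives 1020 nM, a value within the scatter of both other members of this small set. The three values therefore show no separation, and compound 1 is a mid-set reference rather than an extreme.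

The next compound is compound 4 `COc1ccc(/C=C/C(=O)Nc2cc(-c3ccc(C)cc3)[nH]n2)cc1`, which keeps the rest of compound 1 and carries methoxy in place of trifluoromethyl on an aromatic carbon, para to a large group: methoxy in place of trifluoromethyl on an aromatic carbon.

Among the measured compounds shown here, one measured step bears directly on this exchange: a 1.2-fold higher number from compound 2 to compound 3 (0.08 log units; within the scatter). It is the same replacement and lies within the scatter. However, compound 2 and compound 3 differ from compound 1 elsewhere in the structure, so this single pair is only an imperfect guide, and no second pair is available to test it.

On that evidence, no change beyond the scatter is expected in this assay, and no firm direction can be assigned. The expected step is a 1.1-fold higher number from compound 1 to compound 4 (0.05 log units; within the scatter), which is an estimate within the scatter.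

For compound 4 the estimated value is 1150 nM, with an expected range from 550 nM to 2300 nM.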

Compound 4, half-maximal inhibitory concentration: 1190 nM
For compound 4 the middle estimate is 1.0-fold (0.01 log units) below the measured one; measured number inside the range.
By their numbers in this assay, from the lowest: compounds 2, 1, 3 and 4 (each within the scatter of the next).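

Read in this assay on the core of compound 1, methoxy in place of trifluoromethyl on an aromatic carbon, para to a large group, gives a 1.2-fold higher number from compound 1 to compound 4 (0.07 log units; within the scatter) and so no separation between the two groups. The exchange, until now known from a single pair, can therefore be read on two cores, and the two steps agree: the same change on two cores in this assay, a 1.2-fold higher number (0.08 log units; within the scatter) from compound 2 to compound 3 and a 1.2-fold higher number (0.07 log units; within the scatter) from compound 1 to compound 4, 1.0-fold (0.01 log units) apart, within the scatter of two such steps

On both cores, then, trifluoromethyl and methoxy cannot be told apart at this position, even though only methoxy counts a hydrogen-bond acceptor and the two groups differ in heavy atoms.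

Still open, going by these compounds, is whether this position responds to any group at all, since an amine, a carboxylic acid or a longer chain such as butoxy in the same place might yet give a step beyond the scatter. The agreement also rests on these two pairs and this single cell line, so it says nothing yet about other cores or other cells.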